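A few compounds are considered here, and "the series" means these few. Any claim that something is new, unique, unknown or untested is made for them only; others in the source may bear on it.

This account follows a small set of compounds tested in a functional assay on HCT-116 cells (Homo sapiens) for inhibition, read by MTT assay, with a stated time of 72 h; on this read-out lower numbers stand for stronger inhibition of growth and higher numbers for weaker inhibition of growth. Within the data shown here, compound 1, with structure `O=C(O)/C=C/c1ccncc1-c1ccc2cc[nH]c2c1`, is the only member with a recorded result: in this assay compound 1 gives > 30000 nM, which is a limit of the assay and not a number, and it marks (the limit of > 30000 nM in this assay, at which 1 of the 3 values shown sits). Compound 3, `Cn1ncc2cc(-c3cnccc3/C=C/C(=O)N3CCOCC3)ccc21`, has no result in this assay; for compound 3 the entry reads "not determined" (no result reported). Compound 2, `CC(C)[C@@H](NC(=O)/C=C/c1ccncc1-c1ccc2ccccc2c1)C(=O)O`, likewise has no single number: in this assay compound 2 is recorded as "not determined" (no result reported). Among the measured compounds shown here, it thus stands apart from the one value shown for compound 1, with one further entry carrying no number at all. Compound 4, `O=C(/C=C/c1ccncc1-c1ccc2ccccc2c1)NC1CC1`, differs from compound 2 in one place: cyclopropyl in place of 1-carboxy-2-methylpropyl on an amide-type nitrogen. For the measured compounds named here, no measured step exists to set the size of this change in this assay; a shift of modest size in either direction, or none beyond the scatter, cannot be told apart here. Compound 4 is expected to give about 8000 nM in this assay, within a range from 1000 nM to 30000 nM.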

Compound 4, concentration for 50% growth inhibition: 6180 nM
Compound 4: middle estimate off by 1.3-fold (0.11 log units), on the high side; the measured number falls inside the stated range.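

No new step can be read from compound 4: compound 2, which differs from it in one place, offers no single number in this assay. What replacing 1-carboxy-2-methylpropyl with cyclopropyl on the amide-type nitrogen does in this assay stays open among the compounds shown.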